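Cytotoxicity notes: acetyl(isopropyl)amino to (dimethylcarbamoyl)amino

The compounds below may be only part of what the source reports. "The series", "measured", "known", "first", "only" and "open" are said of these compounds alone.

In a functional assay on Huh-5-2 cells (Homo sapiens), read by MTT assay (on this read-out lower numbers stand for higher toxicity in this test and higher numbers for lower toxicity in this test), compound 2 `CC(=O)N(c1ccc(-c2ccc(Cl)cc2)c(COc2ccc(-c3nc4cc(C(=O)O)ccc4n3C3CCCCC3)c(F)c2)c1)C(C)C` gives 20000 nM, within the scatter of compound 1 `CN(C)C(=O)c1ccc(-c2ccc(Cl)cc2)c(COc2ccc(-c3nc4cc(C(=O)O)ccc4n3C3CCCCC3)c(F)c2)c1` at 26000 nM. Compound 3 `CN(C)C(=O)Nc1ccc(-c2ccc(Cl)cc2)c(COc2ccc(-c3nc4cc(C(=O)O)ccc4n3C3CCCCC3)c(F)c2)c1` carries (dimethylcarbamoyl)amino in place of acetyl(isopropyl)amino on an aromatic carbon, para to a 4-chlorophenyl group: (dimethylcarbamoyl)amino in place of acetyl(isopropyl)amino on an aromatic carbon. Going by the values given here, the only measured step, a 1.3-fold lower number from compound 1 to compound 2 (0.11 log units; within the scatter), also exchanged the group on this carbon and stayed within the scatter. No shift beyond the scatter is therefore expected in this assay. The expected change is a 1.1-fold higher number from compound 2 to compound 3 (0.04 log units; within the scatter). For compound 3 the estimated value is 22000 nM, with an expected range of 10000 nM to 45000 nM.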

Compound 3, half-maximal cytotoxic concentration: 25000 nM
Compound 3: the middle estimate sits 1.1-fold (0.06 log units) below what was measured; measured number inside the range.
By their numbers in this assay, from the lowest: compounds 2, 3 and 1 (each within the scatter of the next).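

With (dimethylcarbamoyl)amino on the aromatic carbon para to a 4-chlorophenyl group, this assay shows a 1.3-fold higher number from compound 2 to compound 3 (0.10 log units; within the scatter) and a 1.0-fold lower number from compound 1 to compound 3 (0.02 log units; within the scatter) against the two earlier groups. The entering group carries a hydrogen-bond donor that acetyl(isopropyl)amino lacks, yet all three compounds remain within the scatter of one another. Nothing at hand accounts for this result. From the compounds shown here alone, whether a primary amine or a carboxylic acid on this carbon would give a number beyond the scatter remains open. Going by these compounds, the effect of a longer chain on the urea nitrogen also remains open.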